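The source may report more compounds than this note shows. Statements on the series, on what has been measured and on what is new or still open speak of the compounds shown alone.

Of the compounds shown here, three built on one shared core have so far been tested in a functional assay on the whole organism for inhibition, with Cavia porcellus as the target, with stated times of 1 h and 10 min, at a dose of 0.3 mg/kg by the oral route; a higher number here means a stronger effect of the compound at the dose given, a lower number a weaker effect. Compound 1, `Cc1c(CCCC(=O)O)c2cccc(/C=C/c3ccc(OCCCCc4cc(F)c(F)c(F)c4F)cc3)c2n1CC(=O)O`, gives 55%. Compound 2, `Cc1c(F)cccc1CCCCOc1ccc(/C=C/c2cccc3c(CCCC(=O)O)cn(CC(=O)O)c23)cc1`, gives 73%. Compound 3, `O=C(O)CCCc1cn(CC(=O)O)c2c(/C=C/c3ccc(OCCCCOc4ccccc4)cc3)cccc12`, gives 37%, the lowest of the three numbers: compound 1 stands nearest above it and compound 2 furthest above it, and both gaps lie beyond the usual scatter.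

Among the measured compounds shown here, only one measured pair differs in a single place, and it is the one that leads to compound 3: a number 36 percentage points lower from compound 2 to compound 3 (beyond the scatter). That step replaced a fluorine-bearing ring with phenoxy and cost a large amount of inhibition.

Compound 4, `O=C(O)CCCc1cn(CC(=O)O)c2c(/C=C/c3ccc(OCCCCc4c(F)ccc(F)c4F)cc3)cccc12`, has not yet been measured in this assay. Its difference from compound 3 is 2,3,6-trifluorophenyl in place of phenoxy on a saturated chain carbon, four bonds along the chain from an oxygen on an aromatic ring. For the measured compounds named here, this runs in the opposite sense to the measured step, since phenoxy now leaves and a fluorine-bearing ring enters, though the entering ring is not the one that compound 2 carries. Going by the values given here, compound 1 likewise lacks phenoxy and its value lies above that of compound 3, but no single step joins those two, so only their two values speak.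

On that basis compound 4 is expected to move upward, a step of about a number 23 percentage points higher from compound 3 to compound 4 (beyond the scatter). The estimate for compound 4 is 60%, with a range from 40% to 80%.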

Compound 4, a percentage reported as inhibition, in the whole organism at one dose (the size of the read-out at that dose, not a potency) in the Cavia porcellus assay: 45%
For compound 4 the middle estimate is 15 percentage points above the measured one; low and high end bracket the measured number.
By their numbers in the Cavia porcellus assay, from the lowest: compounds 3, 4 and 1 (each within the scatter of the next, the first and the last beyond it); then compound 2.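

In the Cavia porcellus assay, putting 2,3,6-trifluorophenyl where compound 3 carries phenoxy gives a number 8 percentage points higher from compound 3 to compound 4 (within the scatter), so at this place on the chain, removing phenoxy does not by itself restore the response seen with compound 2. The comparison of the two fluorine-bearing rings is clearer, since in the Cavia porcellus assay the change at the same chain carbon gives a number 28 percentage points lower from compound 2 to compound 4 (beyond the scatter): the presence of fluorine on the ring is not enough, and 2,3,6-trifluorophenyl does not stand in for 3-fluoro-2-methylphenyl here. In a physicochemical assay for permeability, using PAMPA, with a stated time of 4 h, at pH 7.4, tested at 50 uM (a lower number here means that the compound crosses the layer more slowly, a higher number that the compound crosses the layer faster), compound 3 gives < 0.05 10^-6 cm/s as a limit of the assay and not a number. In the physicochemical assay compound 4 gives < 0.05 10^-6 cm/s as a limit of the assay and not a number. In the physicochemical assay the step between compound 3 and compound 4 cannot be read, as both results are limits of the assay and not numbers: the limit of < 0.05 10^-6 cm/s in the physicochemical assay, at which 2 of the 2 values shown sit.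

On these data alone, it remains open which feature of 3-fluoro-2-methylphenyl goes with its higher number, a question that a phenyl ring bearing only a methyl group, or a pyridine ring on the same chain carbon, could help to separate. As far as these compounds go, it is also open whether an amine at the end of the chain would give a readable number in the physicochemical assay, and so whether crossing the layer has any link to the inhibition.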